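Mirror-image step within the series

The source may report more compounds than this note shows. Statements on the series, on what has been measured and on what is new or still open speak of the compounds shown alone.

Among the compounds with values here, compound 1 `c1ccc(CCCCNCC[C@@H]2CCC[C@H](c3ccccc3)O2)cc1` stands second highest of the three numbers so far in an assay on membranes from brain for displacement of a labelled ligand from Sigma non-opioid intracellular receptor 1 (Cavia porcellus), read by scintillation counting, with a stated time of 120 min; on this read-out higher numbers stand for weaker inhibition and lower numbers for stronger inhibition: compound 1 gives 15 nM. Compound 3 `c1ccc([C@@H]2CCC[C@H](CCN3CCN(c4ccccc4)CC3)O2)cc1` is its nearest neighbour, and in this assay compound 3 gives 57 nM, a higher number that lies beyond the scatter. Compound 2 `c1ccc([C@@H]2CCC[C@H](CCNCC3CCCCC3)O2)cc1` lies furthest from it, and in this assay compound 2 gives 2.4 nM, a lower number that also lies beyond the scatter. Compound 4 `c1ccc(CCCCNCC[C@H]2CCC[C@@H](c3ccccc3)O2)cc1` has not yet been measured. Its relation to compound 1 is the two compounds have the same atoms and bonds and differ only in configuration as drawn: 2 of 2 stereo elements differ (all stereocentres are inverted: mirror images); a stereocentre at a saturated ring carbon is drawn S in compound 1 and R in compound 4; a stereocentre at a saturated ring carbon is drawn R in compound 1 and S in compound 4. Within the data shown here, no pair of measured compounds in this set differs only in configuration, so nothing here shows how large a mirror-image step is or which way it runs. A moderate step in this assay from compound 1 to compound 4 of a 2.0-fold higher number from compound 1 to compound 4 (0.30 log units; within the scatter) is expected, more likely toward weaker inhibition, though a step the other way cannot be excluded. Compound 4 is estimated at 30 nM in this assay, with a range from 5 nM to 150 nM.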

Compound 4, inhibition constant: 29 nM
Estimate against measurement, compound 4: 1.0-fold (0.01 log units) above; measured number inside the range.
By their numbers in this assay, from the lowest: compound 2; then compounds 1, 4 and 3 (each within the scatter of the next, the first and the last beyond it).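

Within the data shown here, this is the first reading of a configuration step: in this assay, inverting both stereocentres gives a 1.9-fold higher number from compound 1 to compound 4 (0.29 log units; within the scatter). With this side chain, the assay therefore does not separate the two mirror images, and neither absolute configuration can be ranked over the other. The step reads on configuration alone, with no change in any group, and the basis for that reading is: the fact that compounds 1 and 4 differ only in the configuration as drawn

Still open, as far as these compounds go, are the inversion of only one of the two stereocentres and whether a mirror-image step stays this small with the amine side chains of compound 2 and compound 3. Also open, from the compounds shown here alone, is how this assay responds to a longer chain on the amine, or to a fluorine or a hydroxyl on a phenyl group.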